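This account rests on a few compounds, and the source may have more. Where it says the series, first, only, none or still open, it means among the compounds named here.

Compound 1 `CC(=O)c1ccc(-c2nccc3[nH]c(C(C)(C)O)cc23)cc1` carries an acetyl group on the ring attached to the shared core, and in an ADME assay on U2OS cells (Homo sapiens) for cytotoxicity (on this read-out higher numbers stand for lower toxicity in this test and lower numbers for higher toxicity in this test), compound 1 gives "not determined" (no result reported). Whether it harms cells is tested in this assay. For compound 1 no number was reported in this assay, and the same holds for compound 2 `COc1ccccc1-c1nccc2[nH]c(C(C)(C)O)cc12`, for which compound 2 gives "not determined" (no result reported). Among the compounds with values here, only compound 3 `CC(C)(O)c1cc2c(-c3ccc(NC(=O)OCc4ccccc4)cc3)nccc2[nH]1` gives a figure: in this assay compound 3 gives 5500 nM, so there is no measured step against which the change below can be judged.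

Compound 4 `CC(C)(O)c1cc2c(-c3ccc(F)cc3)nccc2[nH]1` differs from compound 1 in one place:
fluoro in place of acetyl on an aromatic carbon
With no number for compound 1, no direction can be read from the data, and no shift beyond the usual scatter is expected from this change alone.

For compound 4 the expected value in this assay is 8000 nM, within a range from 2000 nM to 30000 nM.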

Compound 4, half-maximal cytotoxic concentration: 93600 nM
For compound 4 the middle estimate is 12-fold (1.07 log units) below the measured one, outside the stated range (above it).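

In this assay compound 4 cannot be set against compound 1, which has no single number, so no step can be read between them. Going by these compounds, what replacing acetyl with fluoro does to this read-out stays open. Nothing available explains the value of compound 4.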